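A few compounds are considered here, and "the series" means these few. Any claim that something is new, unique, unknown or untested is made for them only; others in the source may bear on it.

Of the compounds shown here, three built on the same core have been tested in a functional assay on HeLa S3 cells (Homo sapiens) for cytotoxicity, read by WST assay; on this read-out lower numbers stand for stronger inhibition and higher numbers for weaker inhibition. Compound 1 `CC(C)CC(=O)O[C@@H]1OC=C(CO)[C@H]2C[C@H](O)[C@](O)(COC(=O)/C=C\c3ccc(O)cc3)[C@@H]12` gives 4560 nM, compound 3 `CC(C)CC(=O)O[C@@H]1OC=C(CO)[C@H]2C[C@H](O)[C@](O)(COC(=O)/C=C/c3ccc(O)cc3)[C@@H]12` gives 3570 nM, and compound 2 `CC(C)CC(=O)O[C@@H]1OC=C(CO)[C@H]2C[C@H](OC(=O)/C=C\c3ccc(O)cc3)[C@](O)(CO)[C@@H]12` gives 3110 nM. Compound 2 shows the lowest of the three numbers, yet its gaps to compound 3 and to compound 1 both lie within the scatter, so the three cannot be ranked against one another. Going by the values given here, the only step between neighbours that differ in one place is a 1.3-fold lower number from compound 1 to compound 3 (0.11 log units; within the scatter), which rests on (the fact that compounds 1 and 3 differ only in the configuration as drawn).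

Compound 4 `CC(C)CC(=O)O[C@@H]1OC=C(CO[C@@H]2O[C@H](CO)[C@@H](O)[C@H](O)[C@H]2O)[C@H]2C[C@H](OC(=O)/C=C\c3ccc(O)cc3)[C@](O)(CO)[C@@H]12` departs from compound 2 by 3,4,5-trihydroxy-6-(hydroxymethyl)oxan-2-yl in place of hydrogen on an oxygen on a saturated carbon, the change sitting on an oxygen on a saturated carbon whose other neighbour is a saturated chain carbon. Among the compounds with values here, no measured step involves a change of this kind: the single measured step concerns configuration alone and was within the scatter, so it gives no guide to the size or direction of this one. Compound 4 is therefore expected to give about 5000 nM in this assay, between 2000 nM and 15000 nM. The expected step is a 1.6-fold higher number from compound 2 to compound 4 (0.21 log units; within the scatter).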

Compound 4, half-maximal inhibitory concentration: 4670 nM
For compound 4 the middle estimate is 1.1-fold (0.03 log units) above the measured one, within the range that was stated.
By their numbers in this assay, from the lowest: compounds 2, 3, 1 and 4 (each within the scatter of the next).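

Going by these compounds alone, the earlier compounds carried nothing but hydrogen on this oxygen, so compound 4 is the first to show a substituent there, with 3,4,5-trihydroxy-6-(hydroxymethyl)oxan-2-yl on an oxygen on a saturated carbon. In this assay the change amounts to a 1.5-fold higher number from compound 2 to compound 4 (0.18 log units; within the scatter), so a whole added ring at this position leaves the number indistinguishable from that of compound 2, and no gain or loss can be claimed for it. Nothing in the available evidence bears on this particular result.

The compounds shown leave open whether a methyl ether, an acetyl ester or an amine in place of the hydroxy would move the number beyond the scatter. They also leave open whether the same oxan-2-yl group would behave alike on the other hydroxy groups of the shared core.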